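This account rests on a few compounds, and the source may have more. Where it says the series, first, only, none or still open, it means among the compounds named here.

Measured compounds:
compound 1, `CC[C@@H]1C(=O)N(C)c2cnc(Nc3ccc(S(=O)(=O)NCCO)cc3)nc2N1C1CCCC1`, 7.86 nM
compound 2, `CCCNC(=O)c1ccc2c(ccn2-c2ncc3c(n2)N(C2CCCC2)[C@H](CC)C(=O)N3C)c1`, 11.4 nM

Both were tested in an assay for inhibition of serine/threonine-protein kinase PLK2 (Homo sapiens), read by FRET and Z'-LYTE, with a stated time of 1 h; a higher number here means a weaker inhibitor, a lower number a stronger inhibitor. Compound 1 gives 7.86 nM there, and compound 2 gives 11.4 nM; the two numbers fall within the usual scatter of each other, so the measurements do not set one apart from the other. Compound 3, `CC[C@@H]1C(=O)N(C)c2cnc(Nc3ccc(S(=O)(=O)NCCCO)cc3)nc2N1C1CCCC1`, has not yet been measured. It differs from compound 1 in one place: hydroxymethyl in place of hydroxy on a saturated chain carbon, two bonds along the chain from a sulfonamide nitrogen. Within the data shown here, no pair of measured compounds shows the effect of such a change, so nothing here sets its size. In this assay the expected step is a 1.1-fold higher number from compound 1 to compound 3 (0.06 log units; within the scatter), not beyond the scatter. Compound 3 is estimated at 9 nM, with a likely range from 4 nM to 20 nM.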

Compound 3, half-maximal inhibitory concentration: 8.16 nM
The estimate for compound 3 lay 1.1-fold (0.04 log units) above the measured number; the range from low to high includes it.
By their numbers in this assay, from the lowest: compounds 1, 3 and 2 (each within the scatter of the next).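

In this assay, going from the 2-hydroxyethyl to the 3-hydroxypropyl group on the sulfonamide nitrogen gives a 1.0-fold higher number from compound 1 to compound 3 (0.02 log units; within the scatter). The assay therefore cannot tell these two chains apart, so at this position hydroxymethyl can stand in place of hydroxy without a measurable cost in inhibition. No other measurement here bears on the reason for this result. The compounds shown leave open whether a longer chain would fare the same, and whether an amine or a carboxylic acid could take the place of the hydroxy group.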